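Notes: amine substituent change on the shared core

A few compounds are considered here, and "the series" means these few. Any claim that something is new, unique, unknown or untested is made for them only; others in the source may bear on it.

Measured in a functional assay on MCF7 cells (Homo sapiens) for inhibition, read by sulforhodamine B assay (on this read-out higher numbers stand for weaker inhibition and lower numbers for stronger inhibition), both entries being limits of the assay:
- compound 1 `O=C1C(NC2CCCC2)=CC(=O)c2c1nc1n2[C@H]2OC[C@@H](O)[C@H]2OC1`: > 16000 nM
- compound 2 `O=C1C(NC2CC2)=CC(=O)c2c1nc1n2[C@H]2OC[C@@H](O)[C@H]2OC1`: > 16000 nM

Compound 2 has no number on this read-out, and its entry of > 16000 nM is a limit. The position shared by the two measured compounds is the limit of > 16000 nM in this assay, at which 2 of the 2 values shown sit.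

The change now followed leads to compound 3 `CCCc1ccc(NC2=CC(=O)c3c(nc4n3[C@H]3OC[C@@H](O)[C@H]3OC4)C2=O)cc1`: 4-propylphenyl in place of cyclopropyl on an amine nitrogen. It places 4-propylphenyl in place of cyclopropyl on an amine nitrogen.

Among the measured compounds shown here, the only measured step at this place is a step that the two limits leave unreadable from compound 1 to compound 2. For the measured compounds named here, it gives no size to carry over, and no measured step shows what the 4-propylphenyl group does here. The expectation therefore rests on the structural change alone, and it is loose. The expected step is an at least 1.6-fold lower number from compound 2 to compound 3 (0.20 log units; that floor lies within the scatter), towards stronger inhibition, with its size uncertain. Another limit reading for compound 3 remains quite possible. In this assay the estimated value for compound 3 is 10000 nM, with an expected range from 2000 nM to 40000 nM.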

Compound 3, half-maximal inhibitory concentration: > 4000 nM
Compound 3: a limit, no number; the forecaster's own chance of this, stated with the estimate: 45%; the middle value does not contradict the limit.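

In this assay compound 3 gives > 4000 nM, which is a limit of the assay and not a number. Among the compounds shown here, no step among compound 1, compound 2 and compound 3 can be read, as each entry is a limit. The compounds shown leave open whether 4-propylphenyl in place of cyclopropyl or cyclopentyl on the amine nitrogen changes inhibition, and by how much.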